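Thiosemicarbazone series: pyrrole in place of chlorophenyl

A few compounds are considered here, and "the series" means these few. Any claim that something is new, unique, unknown or untested is made for them only; others in the source may bear on it.

Working notes. Three compounds of the series are measured: compound 1 `COc1ccc(/C=N/NC(=S)NC(C)(C)[C@H]2CC=C(C)CC2)cc1`, compound 2 `CC1=CC[C@H](C(C)(C)NC(=S)N/N=C/c2ccccc2O)CC1` and compound 3 `CC1=CC[C@H](C(C)(C)NC(=S)N/N=C/c2ccccc2Cl)CC1`, all on the shared core. In a functional assay on NCI/ADR-RES cells (Homo sapiens) for inhibition, read by sulforhodamine B assay, with a stated time of 48 h (on this read-out higher numbers stand for weaker inhibition of growth and lower numbers for stronger inhibition of growth), compound 1 gives 50400 nM and compound 2 gives 10900 nM. For compound 3 the assay reports only a limit, > 100000 nM. Compound 3 thus stands at the weak end of the numbers shown, sitting at the limit of > 100000 nM in this assay, at which 1 of the 3 values shown sits. The measured steps run a 4.6-fold lower number from compound 1 to compound 2 (0.67 log units; beyond the scatter), an at least 1.9-fold higher number from compound 1 to compound 3 (0.29 log units; that floor lies within the scatter) and an at least 9.1-fold higher number from compound 2 to compound 3 (0.96 log units; beyond the scatter).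

Compound 4 `CC1=CC[C@H](C(C)(C)NC(=S)N/N=C/c2ccc[nH]2)CC1` differs from compound 3 by 1H-pyrrol-2-yl in place of 2-chlorophenyl on a carbon with a double bond to nitrogen. Within the data shown here, of the measured steps, the one from compound 2 to compound 3 bears most directly on this change, since the entering group brings a hydrogen-bond donor, which compound 2 also carries and compound 3 lacks; that step was an at least 9.1-fold higher number from compound 2 to compound 3 (0.96 log units; beyond the scatter). A lower number than compound 3 is therefore expected in this assay, though the aromatic ring also shrinks, so the full return to compound 2 is not assumed. Compound 4 is expected at 30000 nM, with a range of 8000 nM to 100000 nM. The expected step is an at least 3.3-fold lower number from compound 3 to compound 4 (0.52 log units; beyond the scatter).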

Compound 4, concentration for total growth inhibition: > 100000 nM
Compound 4 ended at the assay's limit; the forecaster's own chance of this, stated with the estimate: 25%; middle value at least 3.3-fold (0.52 log units) from the limit.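

In this assay, a hydrogen-bond donor on the carbon with a double bond to nitrogen is not enough by itself: replacing 2-hydroxyphenyl with 1H-pyrrol-2-yl gives an at least 9.1-fold higher number from compound 2 to compound 4 (0.96 log units; beyond the scatter). Replacing 4-methoxyphenyl with 1H-pyrrol-2-yl gives an at least 1.9-fold higher number from compound 1 to compound 4 (0.29 log units; that floor lies within the scatter), so no order is claimed for that pair. Compound 3 and compound 4 both rest at a limit of the assay, so the step between them cannot be read and 1H-pyrrol-2-yl and 2-chlorophenyl cannot be ranked: the limit of > 100000 nM in this assay, at which 2 of the 4 values shown sit.

As far as these compounds go, it remains open whether the stronger inhibition of growth seen with 2-hydroxyphenyl depends on the hydroxy group itself. An amine in its place on the aromatic carbon would test this.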